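Swapping a hydroxyethyl amide for a pyrrolidine amide

The source may report more compounds than this note shows. Statements on the series, on what has been measured and on what is new or still open speak of the compounds shown alone.

Of the compounds shown here, two built on one shared core have been tested so far in a functional assay on the whole organism with Rattus norvegicus as the target, at a dose of 20 mg/kg by the oral route; on this read-out lower numbers stand for less inhibition and higher numbers for more inhibition at the one dose given (going by the name of the read-out). Compound 1 `NC(=O)/C=C1\CCc2cc(Cl)ccc21` gives 29%. Compound 2 `O=C(/C=C1\CCc2ccc(F)cc21)NCCO` gives 78%. Compound 2 therefore stands highest of the two numbers measured, and its nearest neighbour, compound 1, sits below it by a distance that goes beyond the scatter of repeated measurements. Compound 3 `O=C(/C=C1\CCc2ccc(F)cc21)N1CCCC1` has not yet been measured. It differs from compound 2 in one place: pyrrolidin-1-yl in place of (2-hydroxyethyl)amino on a carbonyl carbon. Among the measured compounds shown here, no step between two measured compounds that differ in only one place is available, so the size of this change cannot be read off from a parallel case. The entering group carries none of the hydrogen-bond donors counted for the leaving group, and on that basis a drop in this assay is expected for compound 3, of a size that may exceed the scatter while still leaving it above compound 1. For compound 3 a value of 55% is expected, within a range from 25% to 85%. That amounts to an expected step of a number 23 percentage points lower from compound 2 to compound 3 (beyond the scatter).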

Compound 3, a percentage reported as inhibition, in the whole organism at one dose (the size of the read-out at that dose, not a potency): 18%
Compound 3: middle estimate off by 37 percentage points, on the high side; measured number below the stated range.
By their numbers in this assay, from the lowest: compound 3; then compound 1; then compound 2.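

In this assay, the group on the carbonyl carbon proves to matter a great deal on the shared core: pyrrolidin-1-yl in place of (2-hydroxyethyl)amino gives a large step, a number 60 percentage points lower from compound 2 to compound 3 (beyond the scatter). This single change alters several features at once, since an open chain ending in a hydroxyl group, with the hydrogen-bond donors and the acceptor counted for it, gives way to a five-membered ring with none of these, so the step alone cannot show which feature matters. Nothing available here accounts for a fall of this size.

Still open, as far as these compounds go, is whether the read-out follows the hydroxyl group, the amide hydrogen or the ring, and groups such as ethylamino, 2-methoxyethylamino or morpholin-4-yl on the same carbonyl carbon would help pull these features apart. From the compounds shown here alone, with a single step at a single oral dose, it also remains open whether the same change would have a similar effect on another core or at another dose.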